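The compounds below may be only part of what the source reports. "The series", "measured", "known", "first", "only" and "open" are said of these compounds alone.

Measured so far in a physicochemical assay for lipophilicity, in phosphate buffer, measured as octanol-water partition, with a stated time of 24 h; on this read-out higher numbers stand for higher lipophilicity and lower numbers for lower lipophilicity:

compound 1, `Cc1ccc(Oc2ccc(/C=N/NC(=O)CSc3nc4ccccc4s3)cc2)cc1`: 5.7
compound 2, `Brc1ccc(Oc2ccc(/C=N/Nc3nc4ccccc4s3)cc2)cc1`: 5.5
compound 3, `C(=N/Nc1nc2ccccc2s1)\c1ccc(Oc2ccc3ccccc3c2)cc1`: 5.6

In this assay compound 2 gives the lowest of the three numbers. The nearest is compound 3, whose value sits higher by an amount within the scatter; the furthest is compound 1, also within the scatter. The three values therefore do not separate from one another, and no ordering among them can be read from this assay.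

The next compound in the series is compound 4, `Fc1ccc(Oc2ccc(/C=N/Nc3nc4ccccc4s3)cc2)cc1`. It differs from compound 2 in one place: fluoro in place of bromo on an aromatic carbon. In words, fluoro in place of bromo on an aromatic carbon, the rest of the structure unchanged.

Within the data shown here, no pair of measured compounds shows this same change, so the size of the step cannot be taken from the numbers in hand. The expectation is nonetheless a fall in this assay, beyond the scatter, when going from compound 2 to compound 4. On that basis compound 4 is expected to give 4.8, with a range from 4.4 to 5.3. The estimated step of a number 0.70 log units lower from compound 2 to compound 4 (beyond the scatter) is what that number means.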

Compound 4, partition coefficient: 5
Compound 4: middle estimate off by 0.20 log units, on the low side, within the range that was stated.
By their numbers in this assay, from the lowest: compound 4; then compounds 2, 3 and 1 (each within the scatter of the next).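

In this assay, among these compounds, fluoro in place of bromo on an aromatic carbon para to a large group gives the first readable step (a number 0.50 log units lower from compound 2 to compound 4 (beyond the scatter)). The earlier compounds offered no pair differing in one place, so this position had no measured response until now; it is now shown that exchanging one heavy atom for another on this carbon can move the read-out beyond the scatter, with no ring, net charge, or hydrogen-bond donor or acceptor count altered. No measurement in hand accounts for the size of this step.

On these data alone, one matched pair gives one step and no trend, so it remains open whether the same exchange would give a similar step on another core, such as the core of compound 1. Also open, as far as these compounds go, is where the read-out would fall with chloro, methoxy, an amine or a carboxylic acid on this same aromatic carbon, and whether the values would follow any order across such groups with the rest of the structure unchanged.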